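This account rests on a few compounds, and the source may have more. Where it says the series, first, only, none or still open, it means among the compounds named here.

Of the compounds shown here, three built on one shared core have been measured in an assay for inhibition of MAP/microtubule affinity-regulating kinase 3 (Homo sapiens), read by HTRF, with a stated time of 2 h; a higher number here means a weaker inhibitor, a lower number a stronger inhibitor. Compound 1 `Cn1cc(-c2cnc3c(-c4csc(C(=O)N[C@@H]5CCC[C@@H]5O)c4)cnn3c2)cn1` gives 43 nM, compound 2 `Cn1cc(-c2cnc3c(-c4csc(C(=O)N[C@@H]5CCC[C@H]5O)c4)cnn3c2)cn1` gives 10 nM, and compound 3 `Cn1cc(-c2cnc3c(-c4csc(C(=O)NC(CO)C5CC5)c4)cnn3c2)cn1` gives 9 nM. Compound 2 therefore stands second highest of the three numbers, close to compound 3 and clearly apart from compound 1. The step of a 4.3-fold lower number from compound 1 to compound 2 (0.63 log units; beyond the scatter) rests only on (the fact that compounds 1 and 2 differ only in the configuration as drawn). The step of a 1.1-fold lower number from compound 2 to compound 3 (0.05 log units; within the scatter) replaces the five-membered ring with a three-membered ring and stays within the scatter.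

Compound 4 `Cn1cc(-c2cnc3c(-c4csc(C(=O)N[C@@H]5CCCC[C@@H]5O)c4)cnn3c2)cn1` differs from compound 2 in one place: 2-hydroxycyclohexyl in place of 2-hydroxycyclopentyl on an amide-type nitrogen. For the measured compounds named here, no measured step enlarges this ring from five-membered to six-membered, so the expectation rests on the two steps at hand. The ring replacement from compound 2 to compound 3 moved the number little, while the change in configuration from compound 1 to compound 2 moved it clearly; compound 4 keeps the configuration of compound 2. A small step, not beyond the scatter, is therefore expected in this assay, namely a 1.3-fold higher number from compound 2 to compound 4 (0.11 log units; within the scatter). Compound 4 is estimated at 13 nM, within a range from 5 nM to 35 nM.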

Compound 4, half-maximal inhibitory concentration: 9 nM
For compound 4 the middle estimate is 1.4-fold (0.16 log units) above the measured one, within the range that was stated.
By their numbers in this assay, from the lowest: compounds 3, 4 and 2 (each within the scatter of the next); then compound 1.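

In this assay, this position on the amide-type nitrogen takes 2-hydroxycyclohexyl as well as 2-hydroxycyclopentyl, with no step beyond the scatter from the better-matched ring compound (a 1.1-fold lower number from compound 2 to compound 4 (0.05 log units; within the scatter)) and none from the open-chain cyclopropyl compound (no change at the digits printed from compound 3 to compound 4 (within the scatter)). The stereocentres of compound 4 are drawn as in compound 1, and with that drawing the ring change alone gives a clear step (a 4.8-fold lower number from compound 1 to compound 4 (0.68 log units; beyond the scatter)), so a shift as large as the one seen at the five-membered ring comes here from ring size too. Compound 1 now stands apart from the other three, and the only printed basis for its gap to compound 2 is this: the fact that compounds 1 and 2 differ only in the configuration as drawn.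

As far as these compounds go, the other drawn configuration of 2-hydroxycyclohexyl remains open, so the effect of configuration at the six-membered ring cannot be read. Also open, from the compounds shown here alone, is how an amine in place of the hydroxyl would behave at this position.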